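Replacing thiophen-2-yl with ethynyl on compound 3

This account rests on a few compounds, and the source may have more. Where it says the series, first, only, none or still open, it means among the compounds named here.

In a functional assay on CEM-DNR-bulk cells (Homo sapiens), read by MTT assay, with a stated time of 72 h (on this read-out higher numbers stand for weaker inhibition and lower numbers for stronger inhibition), compound 3 (`CNc1ncnc2c1c(-c1cccs1)cn2[C@@H]1O[C@H](CO)[C@@H](O)[C@H]1O`) gives > 20000 nM, which is a limit and not a number. Compound 2 (`CSc1ncnc2c1c(-c1cccs1)cn2[C@@H]1O[C@H](CO)[C@@H](O)[C@H]1O`) gives > 20000 nM, which is also a limit. Together they form (the limit of > 20000 nM in this assay, at which 2 of the 3 values shown sit), and between them lies a step that the two limits leave unreadable from compound 2 to compound 3. That step therefore offers no size to carry forward.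

Compound 4 (`C#Cc1cn([C@@H]2O[C@H](CO)[C@@H](O)[C@H]2O)c2ncnc(NC)c12`) keeps the methylamino group of compound 3 and changes one group, on an aromatic carbon of a five-membered aromatic ring with 1 nitrogen: ethynyl in place of thiophen-2-yl on an aromatic carbon. Going by the values given here, no measured step covers this exchange. The nearest guide is compound 1 (`C#Cc1cn([C@@H]2O[C@H](CO)[C@@H](O)[C@H]2O)c2ncnc(OC)c12`), which also carries ethynyl and gives 3490 nM, a true number rather than a limit. On the strength of compound 1 at 3490 nM, a value of similar order is expected for compound 4, though the core substituent differs. The expected change, towards stronger inhibition in this assay, is an at least 8.0-fold lower number from compound 3 to compound 4 (0.90 log units; beyond the scatter). For compound 4 the estimated value is 2500 nM, with an expected range of 250 nM to 18000 nM.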

Compound 4, half-maximal inhibitory concentration: 18500 nM
Compound 4: the middle estimate sits 7.4-fold (0.87 log units) below what was measured; the measured number lies above the stated range.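

In this assay, ethynyl in place of thiophen-2-yl on this aromatic carbon gives an at least 1.0-fold lower number from compound 3 to compound 4 (0.03 log units; that floor lies within the scatter), so this exchange shows no change that can be told apart from the scatter. The value of compound 3 is a limit, so only this floor can be read: the limit of > 20000 nM in this assay, at which 2 of the 4 values shown sit. Going by these compounds alone, with ethynyl kept, methylamino in place of methoxy on an aromatic carbon gives a 5.3-fold higher number from compound 1 to compound 4 (0.72 log units; beyond the scatter), the first readable step, so the exchange of that second group moves the number beyond the scatter.

As far as these compounds go, it remains open how a plain amine in place of methylamino would read alongside ethynyl, and whether methoxy would give a lower number with thiophen-2-yl as it does with ethynyl. From the compounds shown here alone, a longer chain such as propynyl in place of ethynyl is likewise open.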